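A Fluorophenyl Analogue Next to Three Unreadable Limits

The compounds below may be only part of what the source reports. "The series", "measured", "known", "first", "only" and "open" are said of these compounds alone.

Compound 1 `C/C(=C\CC/C(C)=C/CC[C@@H]1[C@@]2(C)CCC(=O)C(C)(C)[C@H]2CC[C@@]1(C)O)CC/C=C(\C)C(=O)OCc1cn(-c2ccccc2C)nn1`, compound 2 `C/C(=C\CC/C(C)=C/CC[C@@H]1[C@@]2(C)CCC(=O)C(C)(C)[C@H]2CC[C@@]1(C)O)CC/C=C(\C)C(=O)OCc1cn(-c2ccc(F)c(Cl)c2)nn1` and compound 3 `C/C(=C\CC/C(C)=C/CC[C@@H]1[C@@]2(C)CCC(=O)C(C)(C)[C@H]2CC[C@@]1(C)O)CC/C=C(\C)C(=O)OCc1cn(-c2cccc(C(F)(F)F)c2)nn1` share one core and differ only in the aryl group carried on an aromatic nitrogen. In a functional assay on A549 cells (Homo sapiens) for antiproliferative activity, read by MTT assay, with a stated time of 48 h (a lower number here means a stronger inhibitor, a higher number a weaker inhibitor), compound 1 gives only a limit of > 150000 nM. Compound 2 likewise gives only a limit of > 150000 nM. Compound 3 also gives only a limit of > 150000 nM. Compound 3 therefore stands among three values of which none is a number, and the steps a step that the two limits leave unreadable from compound 1 to compound 2, a step that the two limits leave unreadable from compound 1 to compound 3 and a step that the two limits leave unreadable from compound 2 to compound 3 cannot be sized because of the limit of > 150000 nM in this assay, at which 3 of the 3 values shown sit.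

Compound 4 `C/C(=C\CC/C(C)=C/CC[C@@H]1[C@@]2(C)CCC(=O)C(C)(C)[C@H]2CC[C@@]1(C)O)CC/C=C(\C)C(=O)OCc1cn(-c2cccc(F)c2)nn1` differs from compound 3 by fluoro in place of trifluoromethyl on an aromatic carbon. Going by the values given here, none of the three measured steps bears a readable size, so they offer no direction and no magnitude for this change; they show only that three different aryl groups on the same nitrogen all fail to reach a number. On that basis no step beyond the scatter can be expected, and the estimated step of a number no higher from compound 3 to compound 4 (the limit leaves the size open) is set near zero. Compound 4 is accordingly expected to give about 150000 nM, within 60000 nM to 400000 nM, most probably again reported as a limit rather than a number.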

Compound 4, half-maximal inhibitory concentration: 124000 nM
Beside the measured number, compound 4's estimate is 1.2-fold (0.08 log units) above it; low and high end bracket the measured number.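

In this assay compound 4 is the only one of the four shown that gives a number, 124000 nM. So a 3-fluorophenyl group on the aromatic nitrogen yields a measured value where the three earlier aryl groups yielded only a limit. The steps read an at least 1.2-fold lower number from compound 3 to compound 4 (0.08 log units; that floor lies within the scatter), an at least 1.2-fold lower number from compound 2 to compound 4 (0.08 log units; that floor lies within the scatter) and an at least 1.2-fold lower number from compound 1 to compound 4 (0.08 log units; that floor lies within the scatter); each is only a floor, so none of them establishes a separation beyond the scatter, though the true size of each may be larger. Floors are all that can be given here, and the steps among compound 1, compound 2 and compound 3 cannot be read, because at least one partner in every pair sits at a limit: the limit of > 150000 nM in this assay, at which 3 of the 4 values shown sit.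

The compounds shown leave open whether fluoro in place of trifluoromethyl truly matters, since compound 4 has no second number in this series to be set against. Also open, going by these compounds, is what an amine, a carboxylic acid or a methoxy group on that same aromatic carbon would give in this assay.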